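Anilide Series: Extending the Amine at the Quinoline Position

A few compounds are considered here, and "the series" means these few. Any claim that something is new, unique, unknown or untested is made for them only; others in the source may bear on it.

Two compounds of one shared core have numbers in a functional assay on MCF7 cells (Homo sapiens) for antiproliferative activity, read by MTT assay, with a stated time of 72 h; on this read-out higher numbers stand for weaker inhibition and lower numbers for stronger inhibition. Compound 1 `CNc1cc(C)c2cc(NC(=O)c3ccc(Cl)c(Cl)c3)ccc2n1` gives 2520 nM in this assay. Among the compounds with values here, compound 2 `Cc1cc(N2CCN(C)CC2)nc2ccc(NC(=O)c3ccc(Cl)c(Cl)c3)cc12` gives 3000 nM in this assay, and it stands as the higher of the two numbers, with compound 1 as its only neighbour, the gap lying within the scatter: a 1.2-fold higher number from compound 1 to compound 2 (0.08 log units; within the scatter).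

Compound 3 `Cc1cc(NCCN2CCCCC2)nc2ccc(NC(=O)c3ccc(Cl)c(Cl)c3)cc12` has not yet been measured. Relative to compound 2 it carries (2-(piperidin-1-yl)ethyl)amino in place of 4-methylpiperazin-1-yl on an aromatic carbon. Within the data shown here, the only measured step that bears on this position is the one from compound 1 to compound 2, where a different amine at the same aromatic carbon left the number within the scatter. Among the measured compounds shown here, with that single step as the whole of the evidence, and no measured example of the entering group, a change beyond the scatter in either direction is not expected in this assay, though the uncertainty is wide.

Compound 3 is therefore expected to give about 2600 nM in this assay, with a range from 1000 nM to 7000 nM, corresponding to an estimated step of a 1.2-fold lower number from compound 2 to compound 3 (0.06 log units; within the scatter).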

Compound 3, half-maximal inhibitory concentration: 1190 nM
Compound 3: the middle estimate sits 2.2-fold (0.34 log units) above what was measured; the range from low to high includes it.
By their numbers in this assay, from the lowest: compound 3; then compounds 1 and 2 (each within the scatter of the next).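

Within the data shown here, the step of a 2.5-fold lower number from compound 2 to compound 3 (0.40 log units; beyond the scatter) in this assay is the first to pass beyond the scatter, and it shows that this aromatic carbon next to the ring nitrogen is not indifferent to the amine it carries, as the earlier pair alone might have suggested. Setting (piperidin-1-yl)methyl on the saturated chain carbon of the methylamino group gives a 2.1-fold lower number from compound 1 to compound 3 (0.33 log units; beyond the scatter) and points the same way, so compound 3 holds the lowest number of the three, with both of its steps modest in size. No measurement shown here accounts for this gain.

The compounds shown do not separate the contribution of the ethyl chain from that of the piperidine ring, so a propyl chain in place of the ethyl chain, or a morpholine or dimethylamino group in place of the piperidine, could each move the number differently. They also leave open whether the hydrogen on the linking amine matters, which a methyl group on that nitrogen would test.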